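The source may report more compounds than this note shows. Statements on the series, on what has been measured and on what is new or still open speak of the compounds shown alone.

Measured so far in a functional assay on SK-BR-3 cells (Homo sapiens) for antiproliferative activity, read by MTT assay, with a stated time of 48 h; on this read-out lower numbers stand for stronger inhibition and higher numbers for weaker inhibition: compound 1 `COc1ccc(OC)c(COc2cc(NC(=O)c3ccc4ccccc4c3)ccc2NS(C)(=O)=O)c1` gives 13.3 nM; compound 2 `COc1ccc(OC)c(COc2cc(NC(=O)c3ccc(Br)cc3)ccc2N(C)S(=O)(=O)C(F)(F)F)c1` gives 470 nM; compound 3 `COc1ccc(C(=O)Nc2ccc(N(C)S(=O)(=O)C(F)(F)F)c(OCc3cc(OC)ccc3OC)c2)cc1` gives 110 nM.

Compound 3 stands second highest of the three numbers, nearest to compound 2 and furthest from compound 1. For the measured compounds named here, the only single-point step measured, a 4.3-fold lower number from compound 2 to compound 3 (0.63 log units; beyond the scatter), is methoxy in place of bromo on an aromatic carbon. Compound 4 `COc1ccc(OC)c(COc2cc(NC(=O)c3ccc4ccccc4c3)ccc2N(C)S(=O)(=O)C(F)(F)F)c1` differs from compound 3 by naphthalen-2-yl in place of 4-methoxyphenyl on a carbonyl carbon. Going by the values given here, no measured step matches this change directly; the closest bearing is compound 1, which carries the naphthalen-2-yl group and gives 13.3 nM, though it also differs from compound 4 elsewhere, so its weight is limited. A lower number is therefore expected for compound 4, a 2.2-fold lower number from compound 3 to compound 4 (0.34 log units; beyond the scatter). Compound 4 is estimated at 50 nM, with a range from 15 nM to 170 nM.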

Compound 4, half-maximal inhibitory concentration: 200 nM
The estimate for compound 4 lay 4.0-fold (0.60 log units) below the measured number; the measured number lies above the stated range.
By their numbers in this assay, from the lowest: compound 1; then compounds 3 and 4 (each within the scatter of the next); then compound 2.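

On the carbonyl carbon, naphthalen-2-yl in place of 4-methoxyphenyl gives a 1.8-fold higher number from compound 3 to compound 4 (0.26 log units; within the scatter) in this assay, so these two groups are not separated here, while naphthalen-2-yl in place of 4-bromophenyl gives a 2.4-fold lower number from compound 2 to compound 4 (0.37 log units; beyond the scatter). With naphthalen-2-yl held constant, methyl((trifluoromethyl)sulfonyl)amino in place of methanesulfonamido on an aromatic carbon gives a 15-fold higher number from compound 1 to compound 4 (1.18 log units; beyond the scatter), the largest listed step, so naphthalen-2-yl alone does not carry the low number of compound 1. No evidence on the origin of these steps is available.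

Open, going by these compounds, is whether methanesulfonamido keeps that low number with 4-methoxyphenyl or 4-bromophenyl on the carbonyl carbon. Also open, on these data alone, is how a carboxylic acid or an amine on that aryl ring would read.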